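Same Atoms, Joined Differently: Clearance of Compound 4 in Rat

The source may hold more compounds than are shown below. What is called first, only, known or untested is meant among the compounds shown, and "the series" means these compounds.

Of the compounds shown here, three built on a shared core have been measured in an ADME assay (Rattus norvegicus, strain Han-wistar) for pharmacokinetics, at a dose of 1.5 umol/kg by the intravenous route; on this read-out lower numbers stand for slow clearance and higher numbers for fast clearance. There, compound 1 `COc1cc(F)ccc1-c1ccnc2[nH]c(C3CCN(CC(=O)N(C)C)CC3)cc12` gives 51 mL/min/kg and compound 2 `CC(C)n1nc(-c2ccnc3[nH]c(C4CCN(CC(=O)N(C)C)CC4)cc23)ccc1=O` gives 72 mL/min/kg, two values within the usual scatter of each other. Compound 3 `COc1cc(C(=O)N2CCCC2)ccc1-c1ccnc2[nH]c(C3CCOCC3)cc12` gives 22 mL/min/kg, a number lower than that of compound 2 by more than the scatter. Compound 2 therefore stands at the fast end of this small set, level with compound 1 within the scatter.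

Compound 4 `CC(C)n1cc(-c2ccnc3[nH]c(C4CCN(CC(=O)N(C)C)CC4)cc23)cnc1=O` has the same atoms as compound 2, joined differently: a group of 10 heavy atoms (7 carbon, 2 nitrogen, 1 oxygen; one six-membered aromatic ring with 2 hetero atoms) in place of a group of 10 heavy atoms (7 carbon, 2 nitrogen, 1 oxygen; one six-membered aromatic ring with 2 hetero atoms), on an aromatic carbon. The group sits on an aromatic carbon, opposite the ring nitrogen, and on both sides it holds a six-membered aromatic ring with 2 hetero atoms.

Within the data shown here, only one measured step bears on this change. It is a 1.4-fold higher number from compound 1 to compound 2 (0.15 log units; within the scatter), where a six-membered aromatic ring of carbon only gave way to one with 2 hetero atoms. Among the measured compounds shown here, no measured pair shows the atoms of such a group rearranged, so the evidence is indirect. With that single step inside the scatter, no shift beyond the scatter is expected in this assay.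

The expected change is a 1.2-fold lower number from compound 2 to compound 4 (0.06 log units; within the scatter), a step estimated to stay within the scatter. Compound 4 is estimated at 62 mL/min/kg, with an expected range from 36 mL/min/kg to 95 mL/min/kg.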

Compound 4, clearance in the Rattus norvegicus assay: 72 mL/min/kg
Compound 4: middle estimate off by 1.2-fold (0.06 log units), on the low side; low and high end bracket the measured number.
By their numbers in the Rattus norvegicus assay, from the lowest: compound 3; then compounds 1, 2 and 4 (each within the scatter of the next).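

Among these compounds, at this position, on an aromatic carbon opposite the ring nitrogen, the Rattus norvegicus assay gives the first direct reading of the atoms of the group being rearranged, no change at the digits printed from compound 2 to compound 4 (within the scatter), while the comparison with the six-membered aromatic ring of carbon only in compound 1 gives a 1.4-fold higher number from compound 1 to compound 4 (0.15 log units; within the scatter). The rearrangement is not without effect on every read-out, since in a physicochemical assay for lipophilicity, using the shake flask method, measured as octanol-water partition, at pH 7.4 (on this read-out lower numbers stand for lower lipophilicity and higher numbers for higher lipophilicity), it gives a number 1.60 log units lower from compound 2 to compound 4 (beyond the scatter). In the physicochemical assay compound 2 gives 2 and compound 4 gives 0.4. For this pair, then, a large difference in the distribution coefficient came with no difference in clearance at the digits printed, a separation that no earlier pair could show: the measured distribution coefficient of compound 2, 2, and of compound 4, 0.4, a number 1.60 log units lower (beyond the scatter)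

The compounds shown leave open whether clearance would stay level with a more different group on this aromatic carbon, such as an amine or a carboxylic acid, or with a longer chain in place of the isopropyl group on the ring. They also cannot tell whether the separation between the two read-outs seen for compound 2 and compound 4 extends beyond this single pair.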